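The compounds below may be only part of what the source reports. "The series", "measured", "known", "first", "only" and "open" are said of these compounds alone.

Measured compounds, inhibition of Rho-associated protein kinase 2 on isolated protein:

- compound 1, `COc1cccc(Cn2cnc3sc(-c4ccc5[nH]ncc5c4)cc3c2=O)c1`: 2 nM
- compound 2, `COc1cccc(Cn2cnc3sc(-c4ccnc(C)c4)cc3c2=O)c1`: 42 nM
- compound 3, `COc1cccc(Cn2cnc3sc(-c4ccnc(OC)c4)cc3c2=O)c1`: 6920 nM

In an assay on isolated protein for inhibition of Rho-associated protein kinase 2 (Homo sapiens), read by radiometric assay and 33P incorporation, with a stated time of 40 min, in the presence of a further agent that is not named here (on this read-out higher numbers stand for weaker inhibition and lower numbers for stronger inhibition), compound 3 gives the highest number of the three, the weakest inhibition in this set. Its nearest neighbour is compound 2, reached by the step of a 160-fold higher number from compound 2 to compound 3 (2.22 log units; beyond the scatter); the gap to compound 1 is the step of a 3500-fold higher number from compound 1 to compound 3 (3.54 log units; beyond the scatter). Both steps lie beyond the scatter.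

Compound 4, `COc1cccc(Cn2cnc3sc(-c4ccnc(N)c4)cc3c2=O)c1`, has not been measured in this assay. It differs from compound 3 in one place: amino in place of methoxy on an aromatic carbon.

Within the data shown here, two measured steps bear on this change. The step of a 160-fold higher number from compound 2 to compound 3 (2.22 log units; beyond the scatter) shows that introducing the methoxy onto the pyridinyl group cost a large amount of inhibition; compound 4 removes that methoxy again. The step of a 21-fold higher number from compound 1 to compound 2 (1.32 log units; beyond the scatter) shows that the pyridinyl group as such, with a methyl on it, sits well behind the indazolyl of compound 1. Among the measured compounds shown here, no measured compound carries an amino on this ring, so the size of the step is uncertain, but it is expected to run in the direction of stronger inhibition, back toward compound 2.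

The estimate for compound 4 is a 170-fold lower number from compound 3 to compound 4 (2.24 log units; beyond the scatter) in this assay, giving an expected value of 40 nM with a range from 5 nM to 400 nM.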

Compound 4, half-maximal inhibitory concentration: 1 nM
For compound 4 the middle estimate is 40-fold (1.60 log units) above the measured one; the measured number lies below the stated range.
By their numbers in this assay, from the lowest: compounds 4 and 1 (each within the scatter of the next); then compound 2; then compound 3.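

At this place next to the ring nitrogen, the single replacement of methoxy by amino, a 6900-fold lower number from compound 3 to compound 4 (3.84 log units; beyond the scatter), in this assay goes well beyond restoring the level of the methyl analogue, as a 42-fold lower number from compound 2 to compound 4 (1.62 log units; beyond the scatter) shows, so the outcome depends strongly on which group occupies this position rather than simply on the removal of methoxy. With a 2.0-fold lower number from compound 1 to compound 4 (0.30 log units; within the scatter), the 2-aminopyridin-4-yl and 1H-indazol-5-yl groups cannot be separated here, so the gap between compound 1 and compound 2 does not apply to pyridinyl groups in general. No measurement shown here accounts for the large effect of the amino group.

As far as these compounds go, whether the result is specific to the unsubstituted amino group remains open, and methylamino, dimethylamino, acetamido or hydroxyl at the same place would test this. From the compounds shown here alone, how compound 4 and compound 1 compare on kinases other than this one, and whether the amino group keeps its effect with another group in place of the methoxybenzyl substituent on the shared core, also remains open.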